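Swapping a bulky ether tail for a small methoxymethyl one

This account rests on a few compounds, and the source may have more. Where it says the series, first, only, none or still open, it means among the compounds named here.

Measured compounds:
compound 1 `COc1cc(C(C)(C)C)ccc1C/N=C(\S)NCc1ccc(NS(C)(=O)=O)cc1`, 2400 nM
compound 2 `CC(C)(C)COc1cc(C(C)(C)C)ccc1C/N=C(\S)NCc1ccc(NS(C)(=O)=O)cc1`, 60 nM

Going by the values given here, in a functional assay for inhibition of Vanilloid receptor (Rattus norvegicus) (on this read-out higher numbers stand for weaker inhibition and lower numbers for stronger inhibition), compound 2 has the lowest of the two numbers, the single step being a 40-fold lower number from compound 1 to compound 2 (1.60 log units; beyond the scatter). Compound 3 `COCOc1cc(C(C)(C)C)ccc1C/N=C(\S)NCc1ccc(NS(C)(=O)=O)cc1` is not yet measured; it differs from compound 2 by methoxy in place of tert-butyl on a saturated chain carbon bound to an oxygen on an aromatic ring. Among the compounds with values here, only that one step bears on this change, and it shows a large gain when the tert-butyl enters. Removing it again, even with a methoxy in its place, is therefore expected to give back much of that loss, so the expected step is a 20-fold higher number from compound 2 to compound 3 (1.30 log units; beyond the scatter). The estimate for compound 3 in this assay is 1200 nM, with a range from 300 nM to 4500 nM.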

Compound 3, half-maximal inhibitory concentration: 500 nM
Beside the measured number, compound 3's estimate is 2.4-fold (0.38 log units) above it, within the range that was stated.
By their numbers in this assay, from the lowest: compound 2; then compound 3; then compound 1.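

Placing a methoxy on the saturated chain carbon bound to the ring oxygen still brings a gain, with a 4.8-fold lower number from compound 1 to compound 3 (0.68 log units; beyond the scatter) as the step, so the lower number at this position does not depend on the tert-butyl alone. That gain is only partial, since the change away from tert-butyl gives an 8.3-fold higher number from compound 2 to compound 3 (0.92 log units; beyond the scatter) as its step. No outside data explain the difference between these two groups.

Still open, on these data alone, is how an amine or a longer chain ending in an ether oxygen would compare with tert-butyl at this same carbon.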